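From 4-methyl-1,3-oxazol-2-yl to 5-methyl-1,3-oxazol-2-yl in compound 1

This account rests on a few compounds, and the source may have more. Where it says the series, first, only, none or still open, it means among the compounds named here.

Compound 1 `Cc1coc(Cn2nc3ccc(-c4ccc(OC(F)(F)F)cc4)cn3c2=O)n1`: 2.67 h
Compound 2 `O=c1[nH]nc2ccc(-c3ccc(Oc4ccc(F)cc4)cc3)cn12`: 4.55 h
Compound 3 `O=c1n(Cc2noc(CO)n2)nc2ccc(-c3ccc(Oc4ccc(F)cc4)cc3)cn12`: 3.02 h

These three values come from an ADME assay on microsomes (Canis lupus familiaris) for metabolic stability; a higher number here means that the compound lasts longer, a lower number that the compound disappears faster. Compound 1, at 2.67 h, lies within the usual scatter of both compound 2 and compound 3, so the three cannot be ranked on these numbers.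

Compound 4 `Cc1cnc(Cn2nc3ccc(-c4ccc(OC(F)(F)F)cc4)cn3c2=O)o1` has not yet been measured. It has the same atoms as compound 1, joined differently: 5-methyl-1,3-oxazol-2-yl in place of 4-methyl-1,3-oxazol-2-yl on a saturated chain carbon bound to an aromatic nitrogen. The swap sits on a saturated chain carbon bound to an aromatic nitrogen, and the core is untouched.

Going by the values given here, only one measured step is available, a 1.5-fold lower number from compound 2 to compound 3 (0.18 log units; within the scatter). Among the compounds with values here, it concerns a different change and stays within the scatter, and no measured pair tests this swap directly, so it offers only weak guidance. No shift beyond the scatter is therefore expected in this assay, and the estimated step is a 1.0-fold lower number from compound 1 to compound 4 (0.01 log units; within the scatter). Compound 4 is expected to show 2.6 h, with an estimated range from 1.4 h to 4.6 h.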

Compound 4, half-life: 3.8 h
For compound 4 the middle estimate is 1.5-fold (0.16 log units) below the measured one; measured number inside the range.
By their numbers in this assay, from the lowest: compounds 1, 3, 4 and 2 (each within the scatter of the next).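

In this assay, the exchange of 4-methyl-1,3-oxazol-2-yl for 5-methyl-1,3-oxazol-2-yl on a saturated chain carbon bound to an aromatic nitrogen, with the core untouched, now has a direct reading (a 1.4-fold higher number from compound 1 to compound 4 (0.15 log units; within the scatter)). Going by these compounds alone, the two placements of the methyl group on this oxazole therefore cannot be told apart in this measurement, something the earlier compounds, none of which forms such a pair, could not show. Nothing on hand explains this result or ties it to any property of either group.

Going by these compounds, how an amine or a carboxylic acid on the oxazole, or a longer chain in place of the single saturated carbon, would read in this assay remains open. Also open, on these data alone, is whether the same exchange would read alike on the core of compound 3.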